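The source may report more compounds than this note shows. Statements on the series, on what has been measured and on what is new or still open speak of the compounds shown alone.

Compound 1 `CCOC(=O)c1ccc(NCc2cncn2Cc2ccc(-c3ccccc3)cc2)cc1-c1ccccc1`: > 10000 nM
Compound 2 `CC(C)OC(=O)c1ccc(NCc2cncn2Cc2ccc(-c3ccccc3)cc2)cc1-c1ccccc1`: > 10000 nM
Compound 3 `c1ccc(-c2ccc(Cn3cncc3CNc3ccc(-c4nc5ccccc5o4)c(-c4ccccc4)c3)cc2)cc1`: > 10000 nM

These three compounds were tested in a toxicity assay on NIH3T3 cells (Mus musculus) for cytotoxicity, read by resazurin assay; on this read-out higher numbers stand for an effect only at larger amounts of compound and lower numbers for an effect already at smaller amounts. Each entry is a limit of the assay and not a number: the limit of > 10000 nM in this assay, at which 3 of the 3 values shown sit. Compound 3 therefore has no exact position, only its limit of > 10000 nM.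

Compound 4 `c1ccc(-c2ccc(Cn3cncc3CNc3ccc(-c4onc5ccccc45)c(-c4ccccc4)c3)cc2)cc1` has the same atoms as compound 3, joined differently, and the change lies in one group: a group of 9 heavy atoms (7 carbon, 1 nitrogen, 1 oxygen; one five-membered aromatic ring with 2 hetero atoms, one six-membered aromatic ring of carbon only) in place of a group of 9 heavy atoms (7 carbon, 1 nitrogen, 1 oxygen; one five-membered aromatic ring with 2 hetero atoms, one six-membered aromatic ring of carbon only), on an aromatic carbon. The 1,3-benzoxazol-2-yl leaves an aromatic carbon, ortho to a phenyl group, and a new group enters there.

Two measured steps changed the group at this carbon: a step that the two limits leave unreadable from compound 1 to compound 3 and a step that the two limits leave unreadable from compound 2 to compound 3. Neither gives a size to carry over, so the data support no direction for the new step. In this assay, no step beyond the usual scatter is therefore expected, and the expected step is a number no higher from compound 3 to compound 4 (the limit leaves the size open). A report at the same limit is the most likely outcome. For compound 4 the estimated value is 10000 nM, with an expected range from 4000 nM to 25000 nM.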

Compound 4, half-maximal effective concentration: > 10000 nM
Compound 4 ended at the assay's limit; the forecaster's own chance of this, stated with the estimate: 80%; the middle value sits exactly at the limit.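

In this assay compound 4 gives > 10000 nM, which is a limit of the assay and not a number. Its steps from compound 1, compound 2 and compound 3 therefore cannot be read: the limit of > 10000 nM in this assay, at which 4 of the 4 values shown sit.

The compounds shown leave open at what amount any of them would affect these cells, and whether changing the group on this aromatic carbon makes any difference.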